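Removal of the methyl from compound 3

The source may hold more compounds than are shown below. What is called first, only, known or untested is meant among the compounds shown, and "the series" means these compounds.

Three analogues sharing one core have numbers in a functional assay on MDA-MB-231 cells (Homo sapiens) for antiproliferative activity, read by sulforhodamine B assay, with a stated time of 48 h; on this read-out lower numbers stand for stronger inhibition and higher numbers for weaker inhibition. Compound 1 `COc1cc(OC)c2sc(-c3ccc(N/C=C\C(=O)c4cc(OC)c(OC)c(OC)c4)cc3)nc2c1` gives 15800 nM. Compound 2 `COc1cc(OC)c2sc(-c3ccc(N/C=C\C(=O)c4ccc(OC)c(F)c4)c(C)c3)nc2c1` gives 13300 nM. Going by the values given here, compound 3 `COc1cc(OC)c2sc(-c3ccc(N/C=C\C(=O)c4ccc(OC)c([N+](=O)[O-])c4)c(C)c3)nc2c1` gives 10800 nM, the lowest of the three, though compound 2 and compound 1 both lie within the scatter of it; the only single-site step, a 1.2-fold lower number from compound 2 to compound 3 (0.09 log units; within the scatter), is likewise within the scatter.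

Compound 4 `COc1cc(OC)c2sc(-c3ccc(N/C=C\C(=O)c4ccc(OC)c([N+](=O)[O-])c4)cc3)nc2c1` differs from compound 3 by hydrogen in place of methyl on an aromatic carbon. Among the compounds with values here, no measured pair differs only in this way, so no step bears on it directly; compound 1 and compound 3 differ here and in a second place, and their values sit within the scatter of each other. Compound 4 is therefore expected to show a step of a 1.0-fold higher number from compound 3 to compound 4 (0.01 log units; within the scatter) of no size beyond the scatter. The estimate for compound 4 is 11000 nM, ranging from 5500 nM to 22000 nM.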

Compound 4, half-maximal inhibitory concentration: 12900 nM
For compound 4 the middle estimate is 1.2-fold (0.07 log units) below the measured one, within the range that was stated.
By their numbers in this assay, from the lowest: compounds 3, 4, 2 and 1 (each within the scatter of the next).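

Hydrogen in place of methyl on the aromatic carbon gives a 1.2-fold higher number from compound 3 to compound 4 (0.08 log units; within the scatter) and is the first direct reading at this position: with the 4-methoxy-3-nitrophenyl group in place, the methyl makes no difference beyond the scatter. The step of a 1.2-fold lower number from compound 1 to compound 4 (0.09 log units; within the scatter) puts 4-methoxy-3-nitrophenyl in place of 3,4,5-trimethoxyphenyl on the carbonyl carbon, and this change of aryl group also stays within the scatter. No available evidence bears on these results.

On these data alone, whether an ethyl or an amine in place of this methyl, or a carboxylic acid in place of the nitro, would move the number beyond the scatter remains open.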